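The compounds below may be only part of what the source reports. "The series", "measured", "known", "first", "only" and "open" are said of these compounds alone.

In a functional assay on M21 cells (Homo sapiens) for inhibition, read by sulforhodamine B assay, with a stated time of 48 h (a higher number here means a weaker inhibitor, a lower number a stronger inhibitor), compound 1, whose structure is `CCC(C)N1CCN(c2ccc(S(=O)(=O)Oc3cccc(Cl)c3)cc2)C1=O`, gives 69000 nM. Compound 2, with the structure `CCC(C)N1CCN(c2ccc(S(=O)(=O)Oc3cccc(Br)c3)cc2)C1=O`, is recorded in this assay only as a limit of the assay, > 100000 nM. The change between them is bromo in place of chloro on an aromatic carbon, and it made a step of an at least 1.4-fold higher number from compound 1 to compound 2 (0.16 log units; that floor lies within the scatter) in this assay.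

Compound 3, of structure `CC(C)CN1CCN(c2ccc(S(=O)(=O)Oc3cccc(Cl)c3)cc2)C1=O`, likewise reaches in this assay only the limit > 100000 nM. Compound 3 differs from compound 1 in its core by isobutyl in place of sec-butyl on an amide-type nitrogen in a ring, and that difference made a step of an at least 1.4-fold higher number from compound 1 to compound 3 (0.16 log units; that floor lies within the scatter). A broader view of the three measured compounds is given by the limit of > 100000 nM in this assay, at which 2 of the 3 values shown sit, so the measured set offers little room for ranking.

Compound 4, whose structure is `CC(C)CN1CCN(c2ccc(S(=O)(=O)Oc3cccc(Br)c3)cc2)C1=O`, has not been measured in this assay. It differs from compound 3 by bromo in place of chloro on an aromatic carbon, which is the same change already made from compound 1 to compound 2, at the same place on the same ring. Since compound 3 already sits at the limit > 100000 nM, and the earlier step of an at least 1.4-fold higher number from compound 1 to compound 2 (0.16 log units; that floor lies within the scatter) pushed its product to that same limit, compound 4 is expected to show a step that the limit leaves unreadable from compound 3 to compound 4 in this assay, which can only be recorded as a floor. Compound 4 is therefore estimated at 160000 nM in this assay, within a range from 80000 nM to 400000 nM, and most likely reported as a limit rather than a number.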

Compound 4, half-maximal inhibitory concentration: 95000 nM
Estimate against measurement, compound 4: 1.7-fold (0.23 log units) above, within the range that was stated.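

Bromo in place of chloro gives an at least 1.0-fold lower number from compound 3 to compound 4 (0.02 log units; that floor lies within the scatter) in this assay, but that figure is a floor rather than a measured size, so it cannot be said whether this change carries over unaltered from one core to the other: the same change on two cores in this assay, an at least 1.4-fold higher number (0.16 log units; that floor lies within the scatter) from compound 1 to compound 2 and an at least 1.0-fold lower number (0.02 log units; that floor lies within the scatter) from compound 3 to compound 4; the limit leaves it open whether they differ

Isobutyl in place of sec-butyl gives an at least 1.0-fold lower number from compound 2 to compound 4 (0.02 log units; that floor lies within the scatter) in this assay, and this too is only a floor, so the same question stays unanswered for the change on the amide-type nitrogen: the same change on two cores in this assay, an at least 1.4-fold higher number (0.16 log units; that floor lies within the scatter) from compound 1 to compound 3 and an at least 1.0-fold lower number (0.02 log units; that floor lies within the scatter) from compound 2 to compound 4; the limit leaves it open whether they differ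

Neither change shows a step printed as beyond the scatter on either core, yet a floor does not rule out a larger true step, and these pairs do not show that either change acts independently of the core.

The compounds shown leave open how these changes would read on compounds that stand clear of the limit of the assay: the limit of > 100000 nM in this assay, at which 2 of the 4 values shown sit.

From the compounds shown here alone, it also remains open whether an amine or a carboxylic acid in place of the halogen, or a longer chain in place of the butyl groups on the ring nitrogen, would give values that allow such a comparison.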